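Swapping the imidazole for tert-butyl on the amide nitrogen

A few compounds are considered here, and "the series" means these few. Any claim that something is new, unique, unknown or untested is made for them only; others in the source may bear on it.

Of the compounds shown here, three sharing one core have been measured, and they differ only in the group on the amide nitrogen. Compound 1 `Cc1ccc(OCC(=O)N(Cc2cccs2)c2cnn(C)c2)cc1` gives 63000 nM in an assay on HEK293 cells for agonist activity at transient receptor potential cation channel subfamily M member 8 (Homo sapiens), read by fluorescence and calcium flux, with a stated time of 15 min; a higher number here means that more compound is needed for the effect, a lower number that less compound is needed. Compound 2 `Cc1ccc(OCC(=O)N(Cc2cccs2)c2ccncc2)cc1` gives 52 nM, the most potent of the three, and compound 3 `Cc1ccc(OCC(=O)N(Cc2cccs2)c2nccn2C)cc1` gives 1790 nM, the second highest number of the set. The steps are large throughout: a 1200-fold lower number from compound 1 to compound 2 (3.08 log units; beyond the scatter), a 35-fold lower number from compound 1 to compound 3 (1.55 log units; beyond the scatter), and a 34-fold higher number from compound 2 to compound 3 (1.54 log units; beyond the scatter).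

Compound 4 `Cc1ccc(OCC(=O)N(Cc2cccs2)C(C)(C)C)cc1` differs from compound 3 in one place: tert-butyl in place of 1-methyl-1H-imidazol-2-yl on an amide-type nitrogen. Among the compounds with values here, no measured step exchanges a ring for a group without one, so none bears directly on this change. What the three steps do show is that the identity of the group on this nitrogen swings the result enormously, and that the best result so far came with pyridin-4-yl in compound 2. A step beyond the scatter is therefore expected here, most likely toward a higher number, as a 6.7-fold higher number from compound 3 to compound 4 (0.83 log units; beyond the scatter). For compound 4 the estimate is 12000 nM, with a range from 1500 nM to 70000 nM.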

Compound 4, half-maximal effective concentration: 11000 nM
Estimate against measurement, compound 4: 1.1-fold (0.04 log units) above; the range from low to high includes it.
By their numbers in this assay, from the lowest: compound 2; then compound 3; then compound 4; then compound 1.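

In this assay, a group with no ring can still give a result inside the range set by the ring-bearing groups: tert-butyl in place of 1-methyl-1H-imidazol-2-yl gives a 6.1-fold higher number from compound 3 to compound 4 (0.79 log units; beyond the scatter), and tert-butyl in place of 1-methyl-1H-pyrazol-4-yl gives a 5.7-fold lower number from compound 1 to compound 4 (0.76 log units; beyond the scatter). A ring on the amide nitrogen is therefore not needed to reach this range, and having one does not ensure a lower number, as compound 1 shows, while pyridin-4-yl stays well ahead, with a 210-fold higher number from compound 2 to compound 4 (2.33 log units; beyond the scatter). Nothing measured here explains this order.

Going by these compounds, how a plain phenyl ring or pyridin-3-yl on the amide nitrogen would compare with pyridin-4-yl remains open. So does whether a straight chain such as n-butyl would match tert-butyl.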